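Benzyloxycarbonyl in Place of Cyano on Compound 2

The source may hold more compounds than are shown below. What is called first, only, known or untested is meant among the compounds shown, and "the series" means these compounds.

Compound 1 `COc1ccc(-c2cc3c(OC)cc(OC)cc3n(CC(=O)O)c2=O)cc1`: 10000 nM
Compound 2 `COc1ccc(-c2cc3c(OC)cc(OC)cc3n(CCC#N)c2=O)cc1`: 10000 nM

In a functional assay on PC-3 cells (Homo sapiens) for cytotoxicity, read by colorimetric assay and MTT assay (on this read-out lower numbers stand for stronger inhibition and higher numbers for weaker inhibition), level with compound 1, compound 2 gives 10000 nM. Compound 3 `COc1ccc(-c2cc3c(OC)cc(OC)cc3n(CCC(=O)OCc3ccccc3)c2=O)cc1` carries benzyloxycarbonyl in place of cyano on a saturated chain carbon, two bonds along the chain from an aromatic nitrogen. Among the compounds with values here, one measured step bears on this chain: no change at the digits printed from compound 1 to compound 2 (within the scatter). That single step gives no direction, so no shift beyond the scatter is expected in this assay, though the range stays wide. The estimated step is a 1.3-fold lower number from compound 2 to compound 3 (0.10 log units; within the scatter). For compound 3 the expected value is 8000 nM, with an estimated range of 2500 nM to 12000 nM.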

Compound 3, half-maximal inhibitory concentration: 10000 nM
The estimate for compound 3 lay 1.3-fold (0.10 log units) below the measured number; the measured number falls inside the stated range.
By their numbers in this assay, from the lowest: compounds 1, 2 and 3 (each within the scatter of the next).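

In this assay, the step of no change at the digits printed from compound 2 to compound 3 (within the scatter) shows that this place on the chain takes benzyloxycarbonyl, with its six-membered aromatic ring of carbon only, and the number stays put. The step of no change at the digits printed from compound 1 to compound 3 (within the scatter) extends this to (benzyloxycarbonyl)methyl in place of carboxy on the saturated chain carbon bound to the aromatic nitrogen. No measurement at hand accounts for this flat result.

None of the three compounds departs from the others, so the chain has yet to show any group that moves the number. Going by these compounds, whether a primary amine or a longer carbon chain at this place would do so stays open.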